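The source may report more compounds than this note shows. Statements on the series, on what has been measured and on what is new or still open speak of the compounds shown alone.

In a functional assay on NCI-H460 cells (Homo sapiens) for inhibition, read by MTT assay, with a stated time of 72 h (a lower number here means a stronger inhibitor, a higher number a weaker inhibitor), compound 1 (`CCC(=O)Nc1cccc(C(=O)/C=C2/C(=O)Nc3ccccc32)c1`) gives 10300 nM, compound 3 (`Nc1cccc(C(=O)/C=C2/C(=O)Nc3ccccc32)c1`) gives 20400 nM and compound 2 (`O=C1Nc2ccccc2/C1=C\C(=O)c1ccccc1F`) gives 8500 nM. Compound 2 therefore cannot be told apart from compound 1 within the scatter, while its number lies below that of compound 3 by more than the scatter. Compound 4 (`O=C1Nc2ccccc2/C1=C\C(=O)c1ccccc1Br`) differs from compound 2 in one place, with bromo in place of fluoro on an aromatic carbon. Among the measured compounds shown here, the only measured step, a 2.0-fold higher number from compound 1 to compound 3 (0.30 log units; within the scatter), concerns a different place, so no measured step tests this swap. No step beyond the scatter is therefore expected in this assay. The estimated step is a 1.1-fold lower number from compound 2 to compound 4 (0.05 log units; within the scatter). Compound 4 is expected at 7500 nM, within a range of 3500 nM to 16000 nM.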

Compound 4, half-maximal inhibitory concentration: 11000 nM
For compound 4 the middle estimate is 1.5-fold (0.17 log units) below the measured one, and the stated range covers the measured number.
By their numbers in this assay, from the lowest: compounds 2, 1, 4 and 3 (each within the scatter of the next, the first and the last beyond it).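

Among the compounds shown here, this is the first measured step at this position: on an aromatic carbon ortho to a large group, bromo in place of fluoro gives a 1.3-fold higher number from compound 2 to compound 4 (0.11 log units; within the scatter) in this assay. The two halogens therefore cannot be told apart here, even though bromine and fluorine are different atoms. Nothing measured explains this result.

Still open, on these data alone, is whether a group of another kind at this place, such as methoxy or a carboxylic acid, would move the number beyond the scatter. As far as these compounds go, whether bromo elsewhere on this ring would read the same also remains unknown.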